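A Methyl for Methoxy Swap on the Aromatic Ring

The source may report more compounds than this note shows. Statements on the series, on what has been measured and on what is new or still open speak of the compounds shown alone.

Measured so far in a functional assay on NCI-H460 cells (Homo sapiens) for antiproliferative activity; a lower number here means a stronger inhibitor, a higher number a weaker inhibitor:
compound 1 `COc1ccc(N=C2NC(=O)/C(=C\c3ccc(N(C)C)cc3)S2)cc1` gives 2520 nM
compound 2 `CN(C)c1ccc(/C=C2/S/C(=N/c3ccc(Cl)cc3)NC2=O)cc1` gives 2890 nM

Compound 1 at 2520 nM and compound 2 at 2890 nM lie within the usual scatter of repeated measurements, so these numbers cannot rank the two. The next compound, compound 3 `Cc1ccc(N=C2NC(=O)/C(=C\c3ccc(N(C)C)cc3)S2)cc1`, has not yet been tested. It differs from compound 1 in one place (methyl in place of methoxy on an aromatic carbon), with methyl in place of methoxy on an aromatic carbon, para to a large group. Within the data shown here, no measured pair shows what this swap does, so the expectation is only a cautious one: no change beyond the scatter in this assay, in either direction. The expected size of the move is a 1.1-fold higher number from compound 1 to compound 3 (0.05 log units; within the scatter) and it is a rough guess. Compound 3 is estimated at 2800 nM, with an expected range from 1300 nM to 6000 nM and the measurement still to come.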

Compound 3, half-maximal inhibitory concentration: 940 nM
Beside the measured number, compound 3's estimate is 3.0-fold (0.47 log units) above it; measured number outside the range, below it.
By their numbers in this assay, from the lowest: compound 3; then compounds 1 and 2 (each within the scatter of the next).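

In this assay, the change from 4-methoxyphenyl to 4-methylphenyl gives a 2.7-fold lower number from compound 1 to compound 3 (0.43 log units; beyond the scatter), a modest step but one beyond the scatter, so this place on the aromatic ring does respond to the group it carries. Among these compounds, until now, no step between compounds differing in one place had been available, and this first one shows that losing one heavy atom and one hydrogen-bond acceptor here goes with a lower number. Nothing measured for these compounds explains the move, so the step records what happened without saying why.

Going by these compounds, it remains open whether an ethyl group, a trifluoromethyl group or an amine at this same place would lower the number further or raise it again. A single step also cannot show whether this swap would act the same way on another core or in other cell lines.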